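Morpholine amide in place of sulfonamide on the pendant aryl

The compounds below may be only part of what the source reports. "The series", "measured", "known", "first", "only" and "open" are said of these compounds alone.

Measured compounds:
- compound 1, `CS(=O)(=O)Nc1ccc(-c2cc(C(=O)N[C@H]3CCCNC3)c(NC(N)=O)s2)cc1`: 2200 nM
- compound 3, `CC(=O)Nc1cccc(-c2cc(C(=O)N[C@H]3CCCNC3)c(NC(N)=O)s2)c1`: 1800 nM
- compound 2, `NC(=O)Nc1sc(-c2ccccc2)cc1C(=O)NCC1CNCCO1`: "not determined" (no result reported)

Compound 1 and compound 3 share the core and the aminopiperidine amide and differ only in the group on the pendant aryl ring. In a functional assay on HT-29 cells (Homo sapiens) (on this read-out higher numbers stand for an effect only at larger amounts of compound and lower numbers for an effect already at smaller amounts), compound 1 gives 2200 nM, the higher of the two numbers, while compound 3 gives 1800 nM; the gap between them lies within the scatter, so the two stand together. Compound 2 carries a different amide, and in this assay compound 2 stands as "not determined" (no result reported), so it has no result in this assay.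

Compound 4, `NC(=O)Nc1sc(-c2ccc(C(=O)N3CCOCC3)cc2)cc1C(=O)N[C@H]1CCCNC1`, is the next entry. It differs from compound 1 only by (morpholin-4-yl)carbonyl in place of methanesulfonamido on an aromatic carbon. Among the compounds with values here, no step between measured compounds covers this change, so there is nothing in the numbers to lean on beyond the finding that swapping one group on that ring, from compound 1 to compound 3, moved the read-out only within the scatter.

The step from compound 1 to compound 4 is therefore expected to be small, a 1.1-fold higher number from compound 1 to compound 4 (0.06 log units; within the scatter), without a clear direction. For compound 4 the estimate in this assay is 2500 nM, with a range from 600 nM to 10000 nM.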

Compound 4, half-maximal effective concentration: 610 nM
The estimate for compound 4 lay 4.1-fold (0.61 log units) above the measured number; the range from low to high includes it.
By their numbers in this assay, from the lowest: compound 4; then compounds 3 and 1 (each within the scatter of the next).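

In this assay, replacing methanesulfonamido with (morpholin-4-yl)carbonyl gives a 3.6-fold lower number from compound 1 to compound 4 (0.56 log units; beyond the scatter), the first change on the pendant aryl ring shown to move the read-out beyond the scatter; compound 1 and compound 3 had stood together, so the group para to a large group is not as indifferent as that pair suggested. The change also shows that this place accepts a larger group carrying a six-membered non-aromatic ring, with 8 heavy atoms entering and 5 leaving, and that the hydrogen-bond donor of methanesulfonamido can be lost without a higher number, since the entering group has 0 hydrogen-bond donors. No measurement at hand indicates which of these structural differences accounts for the step.

Within the data shown here, the single pair leaves open whether the morpholine ring oxygen, the ring itself or the carbonyl link carries the step. A piperidin-1-ylcarbonyl or dimethylaminocarbonyl group at this place would help to separate these, and a carboxylic acid there would extend the comparison to a group of a different kind.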